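Extending the Ester Chain of Compound 2

The source may report more compounds than this note shows. Statements on the series, on what has been measured and on what is new or still open speak of the compounds shown alone.

Of the compounds shown here, two that share a common core have been measured in an assay on membranes from CHO cells for displacement of a labelled ligand from adenosine receptor A1 (Homo sapiens), read by scintillation counting, with a stated time of 60 min, tested at 1 uM; on this read-out lower numbers stand for less inhibition and higher numbers for more inhibition at the one concentration tested (going by the name of the read-out). Compound 2, `COC(=O)C1=C(C)N(C)C(=O)NC1c1cccs1`, gives 30% in this assay. Compound 1, `CC1=C(C(=O)OCC(C)C)C(c2cccs2)NC(=O)N1`, gives 25%, a value that lies within the usual scatter of what compound 2 shows, so the two cannot be told apart on these numbers. Compound 2 thus stands at one end of a pair whose members are effectively indistinguishable.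

Compound 3, `CC1=C(C(=O)OCC(C)C)C(c2cccs2)NC(=O)N1C`, has not yet been measured in this assay. It differs from compound 2 by a single change: isopropyl in place of hydrogen on a saturated chain carbon bound to an oxygen next to a carbonyl group. The same ester chain already appears in compound 1, where it is paired with the unsubstituted ring nitrogen, and that compound sits within the scatter of compound 2.

Because compound 1 gives 25% and compound 2 gives 30%, compound 3 is expected to land in the same region, with a step of a number 2 percentage points lower from compound 2 to compound 3 (within the scatter) that does not exceed the scatter. The estimate for compound 3 in this assay is 28%, with a range from 10% to 48%.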

Compound 3, a percentage reported as inhibition, at one concentration (the size of the read-out at that concentration, not a potency): 9%
The estimate for compound 3 lay 19 percentage points above the measured number; the measured number lies below the stated range.
By their numbers in this assay, from the lowest: compound 3; then compounds 1 and 2 (each within the scatter of the next).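

In this assay isopropyl in place of hydrogen on a saturated chain carbon bound to an oxygen next to a carbonyl group, which turns methoxycarbonyl into isobutoxycarbonyl, goes with a number 21 percentage points lower from compound 2 to compound 3 (beyond the scatter) while the ring nitrogen carries methyl. Methyl in place of hydrogen on an amide-type nitrogen in a ring goes with a number 16 percentage points lower from compound 1 to compound 3 (beyond the scatter) while the isobutoxycarbonyl chain stays in place, so each of the two places now has a single-change step beyond the scatter, something compound 1 and compound 2 could not give, as they differ in two places. No measurement at hand gives a reason for either step.

The compounds shown leave open whether methyl on that nitrogen would go with a similar step when the ester is methoxycarbonyl, and so whether the two changes act independently of each other. They also leave open how a carboxylic acid, an ethoxycarbonyl group or a longer ester chain would read at this place, and whether these readings at one concentration would hold up as differences in potency.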